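Working notes: from compound 2 to compound 4

This account rests on a few compounds, and the source may have more. Where it says the series, first, only, none or still open, it means among the compounds named here.

Measured compounds:
compound 1 `Cc1ccc(C)c(/C=C(/Sc2ccc(Br)cc2)C(=O)c2ccc(Cl)cc2)c1` — 10000 nM
compound 2 `Cc1ccc(CS/C(=C/c2cc(C)ccc2C)C(=O)c2ccc(Cl)cc2)cc1` — 10000 nM
compound 3 `COc1ccc(S(=O)(=O)/C(=C/c2ccc(Br)cc2)C(=O)c2ccc(Br)cc2)cc1` — 6000 nM

In a functional assay on DU-145 cells (Homo sapiens) for inhibition, read by trypan blue exclusion, with a stated time of 96 h (a lower number here means a stronger inhibitor of growth, a higher number a weaker inhibitor of growth), compound 1 gives 10000 nM, compound 2 gives 10000 nM and compound 3 gives 6000 nM. Among the measured compounds shown here, the one single-point step measured, no change at the digits printed from compound 1 to compound 2 (within the scatter), lies within the scatter. Compound 2 therefore stands level with compound 1 at the digits shown, the two together the highest numbers of the three; compound 3 sits within the scatter of both, so no order among them can be read.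

Compound 4 `Cc1ccc(CS/C(=C/c2ccc(C)s2)C(=O)c2ccc(Cl)cc2)cc1` differs from compound 2 in one place: 5-methylthiophen-2-yl in place of 2,5-dimethylphenyl on a double-bonded chain carbon bound to a double-bonded chain carbon. For the measured compounds named here, no measured step touches the group on this double-bonded chain carbon; the only step known alters the group on sulfur and is itself within scatter. The shared core otherwise stays intact. With nothing to point either way, the expected step of no change at the digits printed from compound 2 to compound 4 (within the scatter) is none beyond the scatter. Compound 4 is thus estimated at 10000 nM, with a range from 4000 nM to 25000 nM.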

Compound 4, concentration for 50% growth inhibition: 50000 nM
Beside the measured number, compound 4's estimate is 5.0-fold (0.70 log units) below it, outside the stated range (above it).
By their numbers in this assay, from the lowest: compounds 3, 1 and 2 (each within the scatter of the next); then compound 4.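

In this assay the place on a double-bonded chain carbon bound to a double-bonded chain carbon responds to substitution, giving a 5.0-fold higher number from compound 2 to compound 4 (0.70 log units; beyond the scatter) when 5-methylthiophen-2-yl stands in place of 2,5-dimethylphenyl. The change on sulfur gave no change at the digits printed from compound 1 to compound 2 (within the scatter) and did not separate its two compounds, so of the two single-place steps shown, only this one moves the number beyond the scatter, towards weaker growth inhibition. Nothing available explains the loss.

The compounds shown do not separate the effects of ring size, ring sulfur and the number of methyl groups; a plain phenyl or a pyridin-2-yl ring at this place would help to tell these apart. As far as these compounds go, it also remains open whether the step holds with 4-bromophenyl on sulfur instead of 4-methylbenzyl.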